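Two Piperidine Variants on a Shared Amide Core

A few compounds are considered here, and "the series" means these few. Any claim that something is new, unique, unknown or untested is made for them only; others in the source may bear on it.

Compound 1, `CC(C(=O)NCc1ccc(C(F)(F)F)nc1N(C)c1ccccc1)c1ccc(NS(C)(=O)=O)c(F)c1`, gives 0.9 nM in a functional assay on CHO-K1 cells for antagonist activity at transient receptor potential cation channel subfamily V member 1 (Homo sapiens), read by FLIPR; a higher number here means a weaker inhibitor, a lower number a stronger inhibitor.
Compound 2, `CC(C(=O)NCc1ccc(C(F)(F)F)nc1N1CCCCC1C)c1ccc(NS(C)(=O)=O)c(F)c1`, gives 2.9 nM in this assay.

Compound 2 holds the higher of these two numbers, set by a 3.2-fold higher number from compound 1 to compound 2 (0.51 log units; beyond the scatter). Compound 3, `CC(C(=O)NCc1ccc(C(F)(F)F)nc1N1CCC(O)CC1)c1ccc(NS(C)(=O)=O)c(F)c1`, has not yet been measured. Its change from compound 2 is 4-hydroxypiperidin-1-yl in place of 2-methylpiperidin-1-yl on an aromatic carbon. Within the data shown here, the only measured step, a 3.2-fold higher number from compound 1 to compound 2 (0.51 log units; beyond the scatter), concerns a different exchange at the same carbon and offers no direct guide to this one, so a step of similar or smaller size, leaning toward a higher number, is expected. Compound 3 is therefore estimated at 5 nM, between 1.5 nM and 20 nM, which means a 1.7-fold higher number from compound 2 to compound 3 (0.24 log units; within the scatter) is expected.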

Compound 3, inhibition constant: "not active" (no number reported)
For compound 3 the study gives words and no number; the estimate stays without a comparison.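

Compound 3 is reported only in words, as "not active", so no step from compound 2 to compound 3 can be read in this assay and nothing shown accounts for this result. Going by these compounds, how far compound 3 lies from compound 2 stays open, as does which part of the exchange matters.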